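Aryl swap on the quinoline-type core: halogen to amine

This account rests on a few compounds, and the source may have more. Where it says the series, first, only, none or still open, it means among the compounds named here.

Compound 3 `CCC1CN2CCC1CC2[C@H](O)c1cc(-c2ccc(F)c(Cl)c2)nc2ccc(OC)cc12` gives the lowest of the three numbers in a functional assay on SK-N-MC cells (Homo sapiens) for inhibition, read by cAMP accumulation (a higher number here means a weaker inhibitor, a lower number a stronger inhibitor), at 14000 nM; compound 1 `CCC1CN2CCC1CC2[C@H](O)c1cc(-c2cccc(C(F)(F)F)c2)nc2ccc(OC)cc12` gives 20000 nM and compound 2 `CCC1CN2CCC1CC2[C@H](O)c1cc(-c2ccc(Cl)cc2Cl)nc2ccc(OC)cc12` gives 28000 nM, and both sit within the scatter of compound 3, so no order among the three can be read. The steps are a 1.4-fold lower number from compound 1 to compound 3 (0.15 log units; within the scatter) and a 2.0-fold lower number from compound 2 to compound 3 (0.30 log units; within the scatter), with a 1.4-fold higher number from compound 1 to compound 2 (0.15 log units; within the scatter) between the other two.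

Compound 4 `CCC1CN2CCC1CC2[C@H](O)c1cc(-c2cccc(N)c2)nc2ccc(OC)cc12` is the next entry, differing from compound 3 by 3-aminophenyl in place of 3-chloro-4-fluorophenyl on an aromatic carbon. No measured step covers a change from a halogenated phenyl to a phenyl bearing a donor and an acceptor; the three steps shown all swap one halogen or trifluoromethyl pattern for another and all stay within the scatter. Going by the values given here, the expectation for a 1.2-fold higher number from compound 3 to compound 4 (0.08 log units; within the scatter) is therefore no step beyond the scatter, with a wider range than the measured steps because the amino group has no precedent here. Compound 4 is estimated at 17000 nM, between 6000 nM and 50000 nM.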

Compound 4, half-maximal inhibitory concentration: > 100000 nM
Compound 4 ended at the assay's limit (the forecaster's own chance of this, stated with the estimate: 10%); middle value at least 5.8-fold (0.76 log units) away from the limit.
By their numbers in this assay, from the lowest: compounds 3, 1 and 2 (each within the scatter of the next). At a limit, above all of these: compound 4.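

In this assay, compound 4 gives a limit of the assay and not a number: the limit of > 100000 nM in this assay, at which 1 of the 4 values shown sits.

This aryl position is not indifferent to what it carries: the swaps among the halogen and trifluoromethyl patterns all stayed within the scatter, whereas 3-aminophenyl gives an at least 7.1-fold higher number from compound 3 to compound 4 (0.85 log units; beyond the scatter), an at least 3.5-fold higher number from compound 2 to compound 4 (0.55 log units; beyond the scatter) and an at least 5.0-fold higher number from compound 1 to compound 4 (0.69 log units; beyond the scatter). All three steps are bounds, so the direction is established but the full size of the change is not.

The compounds shown do not separate the entry of the amino group from the departure of the halogens or the trifluoromethyl. From the compounds shown here alone, whether a hydroxyl, a dimethylamino group or a bare phenyl ring at this position would read like compound 4 or like compound 3 remains open.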